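Dropping one chloro from the dichlorophenyl group

This account rests on a few compounds, and the source may have more. Where it says the series, first, only, none or still open, it means among the compounds named here.

Measured so far:
- compound 1, `COc1cc2c(cc1N1C[C@@H](C)N(C)[C@@H](C)C1)N(C(=O)Nc1cccc(Cl)c1Cl)CC2`: 7.94 nM
- compound 2, `COc1cc2c(cc1N1C[C@@H](C)N(C)[C@@H](C)C1)N(C(=O)c1cccc(Cl)c1Cl)CC2`: 12.6 nM

In an assay on isolated protein for binding affinity to 5-hydroxytryptamine receptor 1B (Homo sapiens) (on this read-out higher numbers stand for weaker inhibition and lower numbers for stronger inhibition), compound 1 gives 7.94 nM, and compound 2 gives 12.6 nM. For the measured compounds named here, compound 2 thus gives the highest of the two numbers, but the only measured step, a 1.6-fold higher number from compound 1 to compound 2 (0.20 log units; within the scatter), lies within the scatter, so the two compounds cannot be told apart on these data.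

Compound 3, `COc1cc2c(cc1N1C[C@@H](C)N(C)[C@@H](C)C1)N(C(=O)c1cccc(Cl)c1)CC2`, keeps the whole of compound 2 except for one change: hydrogen in place of chloro on an aromatic carbon of the six-membered aromatic ring of carbon only, ortho to a chloro group and ortho to a large group. Going by the values given here, no measured step touches this position; the single known step concerns the link between the carbonyl and the ring, not the chloro groups. There is therefore no basis in the data for expecting a large shift in either direction in this assay, and the expected step of a 1.6-fold higher number from compound 2 to compound 3 (0.20 log units; within the scatter) is kept small, with a wide range to reflect the missing information. Compound 3 is accordingly estimated at 20 nM, between 6 nM and 65 nM.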

Compound 3, inhibition constant: 20 nM
Beside the measured number, compound 3's estimate shows no gap at the digits printed; the measured number falls inside the stated range.
By their numbers in this assay, from the lowest: compounds 1, 2 and 3 (each within the scatter of the next, the first and the last beyond it).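

In this assay, hydrogen in place of chloro on an aromatic carbon, ortho to a chloro group and ortho to a large group, gives a 1.6-fold higher number from compound 2 to compound 3 (0.20 log units; within the scatter) on the carbonyl-linked series, so losing this one chlorine cannot be told apart from no effect. The wider comparison, which changes the whole group on the carbonyl carbon, gives (a 2.5-fold higher number from compound 1 to compound 3 (0.40 log units; beyond the scatter)), a modest step and the first here beyond the scatter, even though it spans two steps that each stay within it. Nothing at hand explains either step.

Still open is what a fluoro, methyl or methoxy group would give on that same aromatic carbon, where only chloro and hydrogen appear among the compounds shown. Also open, on these data alone, is whether the remaining chloro matters, which a plain phenyl group on the carbonyl could test.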